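Methoxy for bromo on a pyrazole carboxamide series

The compounds below may be only part of what the source reports. "The series", "measured", "known", "first", "only" and "open" are said of these compounds alone.

Four compounds share one core and differ in the groups at the ends of two rings. Compound 1 `COc1ccc(-c2nn(-c3ccccc3)cc2C(=O)Nc2ccc(Br)cc2)cc1` carries a bromo group on one ring and a methoxy group on the other. In a functional assay on HCT-116 cells (Homo sapiens) for cytotoxicity, read by MTT assay, with a stated time of 48 h (a lower number here means a stronger inhibitor, a higher number a weaker inhibitor), compound 1 gives 5870 nM. Compound 2 `COc1ccc(NC(=O)c2cn(-c3ccccc3)nc2-c2ccc(OC)cc2)cc1` differs from it only by the change (methoxy in place of bromo on an aromatic carbon), and in this assay compound 2 gives 1520 nM, so that a 3.9-fold lower number from compound 1 to compound 2 (0.59 log units; beyond the scatter). Compound 3 `O=C(Nc1ccc(Br)cc1)c1cn(-c2ccccc2)nc1-c1ccc([N+](=O)[O-])cc1` differs from compound 1 by the change (nitro in place of methoxy on an aromatic carbon), and in this assay compound 3 gives 4080 nM, a result that a 1.4-fold lower number from compound 1 to compound 3 (0.16 log units; within the scatter).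

Compound 4 `COc1ccc(NC(=O)c2cn(-c3ccccc3)nc2-c2ccc([N+](=O)[O-])cc2)cc1` has not been measured. Going by the values given here, it differs from compound 3 by the change (methoxy in place of bromo on an aromatic carbon), and this is the same change as the one from compound 1 to compound 2, made at the same place on the same kind of ring. The cores of compound 3 and compound 1 differ only in the way already described for compound 3.

Since the earlier step lowered the number beyond the usual scatter, a similar size of step is expected, although one example is a thin basis and the new core is not the one on which it was seen. The expected step is a 3.4-fold lower number from compound 3 to compound 4 (0.53 log units; beyond the scatter). For compound 4 the estimate in this assay is 1200 nM, with a likely range from 500 nM to 3000 nM.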

Compound 4, half-maximal inhibitory concentration: 1020 nM
For compound 4 the middle estimate is 1.2-fold (0.07 log units) above the measured one; low and high end bracket the measured number.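

In this assay, going by these compounds alone, putting methoxy in place of bromo gives a 4.0-fold lower number from compound 3 to compound 4 (0.60 log units; beyond the scatter), and this step closely matches the one seen when the same change was made on the core of compound 1: the same change on two cores in this assay, a 3.9-fold lower number (0.59 log units; beyond the scatter) from compound 1 to compound 2 and a 4.0-fold lower number (0.60 log units; beyond the scatter) from compound 3 to compound 4, 1.0-fold (0.02 log units) apart, within the scatter of two such steps Putting nitro in place of methoxy gives a 1.5-fold lower number from compound 2 to compound 4 (0.17 log units; within the scatter), so this change stays within the scatter on both cores: the same change on two cores in this assay, a 1.4-fold lower number (0.16 log units; within the scatter) from compound 1 to compound 3 and a 1.5-fold lower number (0.17 log units; within the scatter) from compound 2 to compound 4, 1.0-fold (0.02 log units) apart, within the scatter of two such steps Together, these four compounds show that each change had much the same size on the two cores, so the two changes behave as if they add up here, but each comparison rests on only two steps in one cell assay, and this shows neither why the methoxy change matters nor that it would carry over to a more different core.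

The groups shown are limited to bromo or methoxy on one ring and methoxy or nitro on another, so it remains open whether an amine, a carboxylic acid or a longer chain such as butoxy would fit the same picture. Also open, as far as these compounds go, is what a group on the ring left bare in all four compounds would do, and whether these steps would hold in other cell lines.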